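The compounds below may be only part of what the source reports. "The series", "measured", "known", "first", "only" and "open" are said of these compounds alone.

Compound 1 `COc1cc(OC)c(OC)cc1/C=C/C(=O)c1ccc(Cl)cc1` gives 2.3 ug/mL in a functional assay on cells (Erythrocyte, Rattus norvegicus) for inhibition, read by hemolysis, with a stated time of 1 h; a higher number here means a weaker inhibitor, a lower number a stronger inhibitor.
Compound 2 `COc1cc(OC)c(-c2cc(=O)c3cc(Cl)ccc3o2)cc1OC` gives 2.13 ug/mL in this assay.
Compound 3 `COc1cc(OC)c(OC)cc1/C=C/C(=O)c1ccc(O)cc1` gives 2.29 ug/mL in this assay.

Compound 1 and compound 3 share one core and differ by hydroxy in place of chloro on an aromatic carbon; that step is a 1.0-fold lower number from compound 1 to compound 3 (0.00 log units; within the scatter). Compound 2 has another core, and the difference between the two cores is not broken down here; its number lies within the scatter of both compound 1 and compound 3. Compound 4 `COc1cc(OC)c(-c2cc(=O)c3cc(O)ccc3o2)cc1OC` is not yet measured and differs from compound 2 by hydroxy in place of chloro on an aromatic carbon. This is the same kind of change as from compound 1 to compound 3, though the place differs: in compound 1 the ring is six-membered, of carbon only, with the change para to a large group, whereas in compound 2 the ring is part of a fused or bridged system of two rings, meta to a fused ring and para to a fused ring. The expected step is a 1.0-fold lower number from compound 2 to compound 4 (0.01 log units; within the scatter). That expectation rests on compound 1 and compound 3, where the same change gave a 1.0-fold lower number from compound 1 to compound 3 (0.00 log units; within the scatter). Compound 4 is estimated at 2.1 ug/mL, expected between 1.2 ug/mL and 3.8 ug/mL.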

Compound 4, half-maximal inhibitory concentration: 2.14 ug/mL
For compound 4 the middle estimate is 1.0-fold (0.01 log units) below the measured one, and the stated range covers the measured number.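

Putting hydroxy in place of chloro on the core of compound 2 gives a 1.0-fold higher number from compound 2 to compound 4 (0.00 log units; within the scatter) in this assay. Set beside the earlier step, the change carries from one core to the other with no difference that can be told apart: the same change on two cores in this assay, a 1.0-fold lower number (0.00 log units; within the scatter) from compound 1 to compound 3 and a 1.0-fold higher number (0.00 log units; within the scatter) from compound 2 to compound 4, 1.0-fold (0.00 log units) apart, within the scatter of two such steps. This shows agreement for one pair on each of two cores, but it does not show that the same would hold on a further core or at another place on the ring.

The compounds shown carry only chloro or hydroxy at this place, so how an amine, a carboxylic acid or a longer chain there would read in this assay remains open. From the compounds shown here alone, whether any group at this place can move the number beyond the scatter also remains open.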